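A few compounds are considered here, and "the series" means these few. Any claim that something is new, unique, unknown or untested is made for them only; others in the source may bear on it.

Measured compounds:
compound 1, `O=C1N=C(N2N=C(c3ccccc3)CC2c2ccccc2O)S/C1=C1/C(=O)Nc2ccccc21`, 2130 nM
compound 2, `O=C1N=C(N2N=C(c3ccccc3)CC2c2ccccc2O)S/C1=C1/C(=O)Nc2ccc(Br)cc21`, 240 nM
compound 3, `COc1ccc(C2=NN(C3=NC(=O)/C(=C4\C(=O)Nc5ccccc54)S3)C(c3ccc(OC)cc3)C2)cc1`, 43900 nM

The three measured compounds share a pattern in which a hydroxyphenyl-bearing core and a dimethoxyphenyl-bearing core are each compared, read in a functional assay on cells (Cancer cell lines, Homo sapiens) for cytotoxicity, read by sulforhodamine B assay, with a stated time of 48 h; on this read-out higher numbers stand for weaker inhibition of growth and lower numbers for stronger inhibition of growth. Compound 1 gives 2130 nM in this assay. Compound 2 differs from compound 1 by bromo in place of hydrogen on an aromatic carbon, and this assay records an 8.9-fold lower number from compound 1 to compound 2 (0.95 log units; beyond the scatter). Compound 3, built on the other core, gives 43900 nM in this assay; its number stands well apart from those of compound 1 and compound 2, and the difference between the two cores is not broken down here.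

Compound 4, `COc1ccc(C2=NN(C3=NC(=O)/C(=C4\C(=O)Nc5ccc(Br)cc54)S3)C(c3ccc(OC)cc3)C2)cc1`, has not yet been measured. It differs from compound 3 by bromo in place of hydrogen on an aromatic carbon, the same change that turns compound 1 into compound 2, at the same place on the ring. Going by the values given here, the one measured instance of this change, from compound 1 to compound 2, lowers the number. Among the compounds with values here, since only a single pair shows the step, and that pair sits on a different core, the size carried over to compound 4 is uncertain, and a somewhat smaller effect is allowed for.

On this basis compound 4 is expected to give about 6000 nM in this assay, between 1500 nM and 25000 nM, which would mean an expected step of a 7.3-fold lower number from compound 3 to compound 4 (0.86 log units; beyond the scatter).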

Compound 4, concentration for 50% growth inhibition: 200 nM
Beside the measured number, compound 4's estimate is 30-fold (1.48 log units) above it, and the stated range ends above it.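

In this assay, bromo in place of hydrogen on an aromatic carbon gives a 220-fold lower number from compound 3 to compound 4 (2.34 log units; beyond the scatter), so the change lowers the number on both cores, but its size does not carry over from one core to the other: the same change on two cores in this assay, an 8.9-fold lower number (0.95 log units; beyond the scatter) from compound 1 to compound 2 and a 220-fold lower number (2.34 log units; beyond the scatter) from compound 3 to compound 4, 25-fold (1.39 log units) apart, beyond the scatter of two such steps The direction of the step therefore holds in both pairs shown, while the size seen on one core gives a poor guide to the size on the other. These two pairs do not show why the steps differ. The two cores differ in more than one place, and no single difference between them can be tied to the larger step. Nor do the two pairs show what the same change would do on any further core.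

The compounds shown leave open whether a chloro group or an amine on the same aromatic carbon would also lower the number on both cores, and whether the size would again depend on the core. They also leave open which part of the core governs the size of the step, a question that a series changing one substituent of the core at a time, for instance to a carboxylic acid, could address.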